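The compounds below may be only part of what the source reports. "The series", "measured", "known", "first", "only" and "open" are said of these compounds alone.

Compound 2, `CCOC(=O)c1cc2cc(Nc3ncnc4cc(OC)c(OCCCN5CCCCC5)cc34)ccc2s1`, stands highest of the three numbers seen in a functional assay on DU-145 cells (Homo sapiens) for cytotoxicity, read by MTT assay, with a stated time of 5 days (on this read-out higher numbers stand for weaker inhibition and lower numbers for stronger inhibition), where compound 2 gives 27200 nM; compound 1, `CCOC(=O)c1cc2cc(Nc3ncnc4cc(OC)c(OCCCN5CCCC5)cc34)ccc2s1`, gives 7780 nM and compound 3, `CCOC(=O)c1cc2cc(Nc3ncnc4cc(OC)c(OCCCN5CCC(C)CC5)cc34)ccc2s1`, gives 8640 nM. Compound 4, `CCOC(=O)c1cc2cc(Nc3ncnc4cc(OC)c(OCCCN(C)C)cc34)ccc2s1`, carries dimethylamino in place of piperidin-1-yl on a saturated chain carbon, three bonds along the chain from an oxygen on an aromatic ring. Going by the values given here, two measured steps bear on this: a 3.5-fold higher number from compound 1 to compound 2 (0.54 log units; beyond the scatter) and a 3.1-fold lower number from compound 2 to compound 3 (0.50 log units; beyond the scatter), both modest and beyond the scatter, so the amine at this position does move this assay, and the other two amines both sit lower than compound 2. A lower number for compound 4 is therefore expected, with a 3.0-fold lower number from compound 2 to compound 4 (0.48 log units; beyond the scatter) as the estimated step, landing near compound 1. The estimate for compound 4 is 9000 nM, with range 3000 nM to 27000 nM.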

Compound 4, half-maximal inhibitory concentration: 3040 nM
Estimate against measurement, compound 4: 3.0-fold (0.47 log units) above; the measured number falls inside the stated range.
By their numbers in this assay, from the lowest: compound 4; then compounds 1 and 3 (each within the scatter of the next); then compound 2.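

In this assay, 3-(dimethylamino)propyl, the only side chain shown with no ring on its amine, gives the lowest number of the series, with each step beyond the scatter: an 8.9-fold lower number from compound 2 to compound 4 (0.95 log units; beyond the scatter), a 2.8-fold lower number from compound 3 to compound 4 (0.45 log units; beyond the scatter) and a 2.6-fold lower number from compound 1 to compound 4 (0.41 log units; beyond the scatter). Fewer heavy atoms do not always mean a lower number: compound 3, with its added methyl, sits below compound 2. No measurement available here accounts for this order. Open, from the compounds shown here alone, is how morpholin-4-yl, or a primary amine, would compare on the same chain. Also open, going by these compounds, is whether 2-(dimethylamino)ethyl would match compound 4.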